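A few compounds are considered here, and "the series" means these few. Any claim that something is new, unique, unknown or untested is made for them only; others in the source may bear on it.

Measured so far:
compound 1 `Cc1cc(=O)n(-c2ccccc2OC(F)(F)F)nc1C(=O)Nc1ccc(Oc2ncnc3[nH]ccc23)c(F)c1` — 11700 nM
compound 2 `Cc1cc(=O)n(-c2ccc(Br)cc2F)nc1C(=O)Nc1ccc(Oc2ncnc3[nH]ccc23)c(F)c1` — 26600 nM
compound 3 `Cc1cc(=O)n(-c2ccccc2OC(F)(F)F)nc1C(=O)Nc1ccc(Oc2ncnc3c2ccn3C)cc1` — 27000 nM

In a functional assay on MCF7 cells (Homo sapiens) for cytotoxicity, read by MTT assay, with a stated time of 72 h (a higher number here means a weaker inhibitor, a lower number a stronger inhibitor), compound 1 gives 11700 nM. Compound 2 differs from compound 1 by 4-bromo-2-fluorophenyl in place of 2-(trifluoromethoxy)phenyl on an aromatic nitrogen, and the step is a 2.3-fold higher number from compound 1 to compound 2 (0.36 log units; beyond the scatter). Compound 3 gives 27000 nM in this assay; how its core differs from that of compound 1 is not broken down here. The values of compound 3 and compound 2 lie within the scatter of each other, so no order between them is claimed.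

Compound 4 `Cc1cc(=O)n(-c2ccc(Br)cc2F)nc1C(=O)Nc1ccc(Oc2ncnc3c2ccn3C)cc1` has not yet been measured in this assay. It differs from compound 3 by 4-bromo-2-fluorophenyl in place of 2-(trifluoromethoxy)phenyl on an aromatic nitrogen, the same change, at the same place, as that between compound 1 and compound 2. Among the compounds with values here, the expected step for compound 4 is a 2.0-fold higher number from compound 3 to compound 4 (0.31 log units; beyond the scatter), set beside a 2.3-fold higher number from compound 1 to compound 2 (0.36 log units; beyond the scatter), which is the only measured example of this change. The estimate for compound 4 in this assay is therefore 55000 nM, expected to fall between 25000 nM and 120000 nM, with some chance that so weak an inhibitor is reported only as a limit.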

Compound 4, half-maximal inhibitory concentration: 27700 nM
Estimate against measurement, compound 4: 2.0-fold (0.30 log units) above; the range from low to high includes it.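

The change of 2-(trifluoromethoxy)phenyl to 4-bromo-2-fluorophenyl on the second core, read in this assay, gives a 1.0-fold higher number from compound 3 to compound 4 (0.01 log units; within the scatter). Set beside the step on the first core, this result does not separate the two readings: the same change on two cores in this assay, a 2.3-fold higher number (0.36 log units; beyond the scatter) from compound 1 to compound 2 and a 1.0-fold higher number (0.01 log units; within the scatter) from compound 3 to compound 4, 2.2-fold (0.35 log units) apart, within the scatter of two such steps. The two pairs are therefore compatible with the change carrying over between these cores, but they do not show that it transfers with a fixed size or that the core alters its size.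

Still open, going by these compounds, is how a phenyl group bearing an amine or a carboxylic acid would read at this place on either core. The compounds shown also leave open whether a longer alkyl chain on the same aromatic nitrogen, with no aromatic ring at all, would fit the same comparison.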